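Trimming the Aromatic Substituent of Compound 3

The source may report more compounds than this note shows. Statements on the series, on what has been measured and on what is new or still open speak of the compounds shown alone.

Of the compounds shown here, three have been measured in an assay for inhibition of Amine oxidase [flavin-containing] A (Homo sapiens), read by fluorescence and spectrophotometry, using microsomes, with stated times of 30 min and 20 min; on this read-out lower numbers stand for stronger inhibition and higher numbers for weaker inhibition. Compound 1 `c1ccc2c(c1)Oc1nccnc1N1CCN=C21` returns only a limit, > 100000 nM (the limit of > 100000 nM in this assay, at which 1 of the 3 values shown sits), in this assay. Compound 2 `c1cc(-c2noc(C3CC3)n2)ccc1C1=NCCN1` gives 7370 nM in this assay, and compound 3 `Cc1ccc(-c2nc(-c3ccc(C4=NCCN4)cc3)no2)cc1` gives 2310 nM. Within the data shown here, compound 3 thus stands at the lowest of the two numbers, and the single measured step, a 3.2-fold lower number from compound 2 to compound 3 (0.50 log units; beyond the scatter), is what separates it from compound 2 with 4-methylphenyl in place of cyclopropyl on an aromatic carbon.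

Compound 4 `Cc1nc(-c2ccc(C3=NCCN3)cc2)no1` has not yet been measured. It differs from compound 3 in that (methyl in place of 4-methylphenyl on an aromatic carbon). Among the measured compounds shown here, the only step that bears on this change is a 3.2-fold lower number from compound 2 to compound 3 (0.50 log units; beyond the scatter), where a ring group entering in place of cyclopropyl lowered the number. The change to compound 4 runs in the opposite direction, taking the 4-methylphenyl away, so a step toward higher numbers in this assay is expected, probably of similar or somewhat larger size. Compound 4 is therefore expected to give 10000 nM. Its estimate is expected to fall between 3500 nM and 30000 nM. This amounts to an expected 4.3-fold higher number from compound 3 to compound 4 (0.64 log units; beyond the scatter).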

Compound 4, half-maximal inhibitory concentration: 41100 nM
Estimate against measurement, compound 4: 4.1-fold (0.61 log units) below; measured number outside the range, above it.
By their numbers in this assay, from the lowest: compound 3; then compound 2; then compound 4. At a limit, above all of these: compound 1.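

In this assay, this position on the five-membered aromatic ring tolerates the loss of the 4-methylphenyl far less well than the earlier step suggested: methyl in its place gives an 18-fold higher number from compound 3 to compound 4 (1.25 log units; beyond the scatter) and so costs much more than cyclopropyl did. Methyl also falls behind cyclopropyl, with a 5.6-fold higher number from compound 2 to compound 4 (0.75 log units; beyond the scatter) in the same assay, which places the three groups at this one position in the order 4-methylphenyl, cyclopropyl, methyl, from lowest number to highest. Nothing measured here explains this order.

The compounds shown leave open whether the gain from 4-methylphenyl needs the aromatic ring itself or its methyl, which an unsubstituted phenyl would separate. They also leave open how a longer chain such as n-butyl, or a group carrying an amine, would rank at this position.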